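From Fluoro to Cyano on an Aromatic Carbon

A few compounds are considered here, and "the series" means these few. Any claim that something is new, unique, unknown or untested is made for them only; others in the source may bear on it.

In a physicochemical assay for lipophilicity (on this read-out lower numbers stand for lower lipophilicity and higher numbers for higher lipophilicity), compound 1 (`CCOC(=O)CC1CCC2(CC1)OOCCCOO2`) gives 2.2, while compound 2 (`Fc1ccc(CC2CCC3(CC2)OOCCCOO3)cc1`) gives 4.01, the higher of the two numbers. Compound 3 (`N#Cc1ccc(CC2CCC3(CC2)OOCCCOO3)cc1`) has cyano in place of fluoro on an aromatic carbon, para to a large group: cyano in place of fluoro on an aromatic carbon. For the measured compounds named here, only one measured step is available, a number 1.81 log units higher from compound 1 to compound 2 (beyond the scatter). It is large and beyond the scatter, but it is a change of 4-fluorophenyl in place of ethoxycarbonyl on a saturated chain carbon, so it does not set the size of the new step. The expectation therefore rests on the structural change alone, with a hydrogen-bond acceptor entering where none leaves. A moderate fall, probably beyond the scatter, is expected, a number 0.61 log units lower from compound 2 to compound 3 (beyond the scatter). For compound 3 the estimated value is 3.4, with an expected range from 3 to 3.8.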

Compound 3, partition coefficient: 3.46
Compound 3: middle estimate off by 0.06 log units, on the low side, within the range that was stated.
By their numbers in this assay, from the lowest: compound 1; then compound 3; then compound 2.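

In this assay, the change of fluoro to cyano gives a number 0.55 log units lower from compound 2 to compound 3 (beyond the scatter), which shows that the read-out responds to a single group on an aromatic carbon, para to a large group, with the rest of the molecule unchanged. The earlier step exchanged ethoxycarbonyl for a whole 4-fluorophenyl on a saturated chain carbon and was large and upward, whereas this one is modest and downward, with cyano bringing one hydrogen-bond acceptor where fluoro had none. Nothing available explains why the number falls with this change.

The compounds shown leave open whether the fall goes with the hydrogen-bond acceptor or is particular to cyano, since a single pair cannot separate the two. An amine or a carboxylic acid on the same aromatic carbon would show how far the number moves with other groups there.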